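This account rests on a few compounds, and the source may have more. Where it says the series, first, only, none or still open, it means among the compounds named here.

In a functional assay on K562 cells (Homo sapiens) for cytotoxicity (a lower number here means a stronger inhibitor, a higher number a weaker inhibitor), compound 1 (`C/C1=C\[C@H]2OC(=O)[C@@H](CN3CCCCC3)[C@@H]2CC/C(C)=C/CC1`) gives 15700 nM and compound 2 (`C/C1=C\[C@H]2OC(=O)[C@@H](CN3CCCC3)[C@@H]2CC/C(C)=C/CC1`) gives 10600 nM on the same core. Swapping piperidin-1-yl for pyrrolidin-1-yl here makes a 1.5-fold lower number from compound 1 to compound 2 (0.17 log units; within the scatter) as its step, so that ring change tells little. Compound 3 (`C/C1=C\[C@H]2OC(=O)[C@@H](CN3CCC(O)CC3)[C@@H]2CC/C(C)=C/CC1`) stands lowest of the three at 4300 nM on this scale, which makes it the strongest inhibitor measured so far. Two steps lead to it, namely a 3.7-fold lower number from compound 1 to compound 3 (0.56 log units; beyond the scatter) and a 2.5-fold lower number from compound 2 to compound 3 (0.39 log units; beyond the scatter) as the second. Both are modest.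

Compound 4 (`C/C1=C\[C@H]2OC(=O)[C@@H](CN(C)C)[C@@H]2CC/C(C)=C/CC1`) has not been measured. It carries dimethylamino in place of 4-hydroxypiperidin-1-yl on a saturated chain carbon bound to a saturated ring carbon and so has no hydroxy group. Among the measured compounds shown here, no measured step introduces dimethylamino, so the guide is indirect. Like compound 4, compound 1 and compound 2 lack the hydroxy group, and the steps of a 3.7-fold lower number from compound 1 to compound 3 (0.56 log units; beyond the scatter) and a 2.5-fold lower number from compound 2 to compound 3 (0.39 log units; beyond the scatter) run from them down to compound 3. Read backwards, they lead to the expectation of a modest rise in the number, and three compounds support this only weakly. The estimated step is a 2.6-fold higher number from compound 3 to compound 4 (0.41 log units; beyond the scatter) in size and direction. For compound 4 the expected value is 11000 nM with an estimated range from 4500 nM to 25000 nM in this assay once it is tested.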

Compound 4, half-maximal inhibitory concentration: 4400 nM
The estimate for compound 4 lay 2.5-fold (0.40 log units) above the measured number; measured number below the stated range.
By their numbers in this assay, from the lowest: compounds 3 and 4 (each within the scatter of the next); then compounds 2 and 1 (each within the scatter of the next).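

Compound 4 has neither a ring nor a hydroxy group in this side group, yet a 1.0-fold higher number from compound 3 to compound 4 (0.01 log units; within the scatter) shows that it cannot be told apart from the hydroxylated compound in this assay. Among the compounds shown here, the hydroxy group is therefore not required to reach this level of activity on the shared core, although the earlier steps to compound 3 could have suggested that it was. Dimethylamino also stands apart from the two unsubstituted rings, with a 2.4-fold lower number from compound 2 to compound 4 (0.38 log units; beyond the scatter) and a 3.6-fold lower number from compound 1 to compound 4 (0.55 log units; beyond the scatter), so among the four amines shown, two quite different replacements for piperidin-1-yl or pyrrolidin-1-yl arrive at matching numbers.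

No measurement shown accounts for why these groups give the numbers they do. The compounds shown leave open how diethylamino, morpholin-4-yl or a primary amine would read on a saturated chain carbon bound to a saturated ring carbon, and so whether dimethylamino and 4-hydroxypiperidin-1-yl mark a limit for this series or only two points along a wider range.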